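Methoxy to Hydroxy on a Pyrazole Growth Inhibitor Series

A few compounds are considered here, and "the series" means these few. Any claim that something is new, unique, unknown or untested is made for them only; others in the source may bear on it.

Measured compounds:
compound 1, `COc1cc(C)cc(-c2nn(CC#N)cc2-c2ccc(-c3cccc(C(C)=O)c3)nc2)c1`, 35200 nM
compound 2, `Cc1cc(O)cc(-c2nn(CC#N)cc2-c2ccnc(-c3ccc(Oc4ccccc4)cc3)c2)c1`, 5540 nM
compound 3, `COc1cc(C)cc(-c2nn(CC#N)cc2-c2ccnc(-c3ccc(N(C)C)cc3)c2)c1`, 41600 nM

These three compounds share a core and were tested in a functional assay on OVCAR-8 cells (Homo sapiens) for inhibition, read by sulforhodamine B assay, with a stated time of 48 h; a higher number here means a weaker inhibitor of growth, a lower number a stronger inhibitor of growth. Compound 3 gives the highest number of the three, 41600 nM, but its gap to compound 1 lies within the usual scatter, so those two cannot be told apart. Compound 2 sits clearly lower, beyond the scatter, yet compound 2 differs from compound 3 in two places at once, so its number alone cannot say which change matters.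

Compound 4, `Cc1cc(O)cc(-c2nn(CC#N)cc2-c2ccnc(-c3ccc(N(C)C)cc3)c2)c1`, has not yet been measured. It differs from compound 3 in one place: hydrogen in place of methyl on an oxygen on an aromatic ring. Among the compounds with values here, no measured pair shows this change by itself. Within the data shown here, because compound 2, the only compound carrying the hydroxy, gives 5540 nM, a somewhat lower number is expected for compound 4, with the step of a 2.1-fold lower number from compound 3 to compound 4 (0.32 log units; beyond the scatter) estimated as modest and uncertain. The value for compound 4 in this assay is estimated at 20000 nM, with a range from 5000 nM to 80000 nM.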

Compound 4, concentration for total growth inhibition: 69400 nM
Estimate against measurement, compound 4: 3.5-fold (0.54 log units) below; low and high end bracket the measured number.
By their numbers in this assay, from the lowest: compound 2; then compounds 1, 3 and 4 (each within the scatter of the next).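

In this assay, within the data shown here, methoxy to hydroxy on the 3-methoxy-5-methylphenyl group is the only change behind a 1.7-fold higher number from compound 3 to compound 4 (0.22 log units; within the scatter) and so, with dimethylamino in place, this swap on the oxygen has no effect that can be told from scatter. With the hydroxy held fixed, dimethylamino in place of phenoxy gives a 13-fold higher number from compound 2 to compound 4 (1.10 log units; beyond the scatter) and so, among these compounds, the lower number of compound 2 goes with its phenoxy group and not with the hydroxy alone. Nothing measured here bears on why either step comes out as it does.

From the compounds shown here alone, whether methoxy to hydroxy would read the same with phenoxy in place of dimethylamino stays open. Also open, going by these compounds, is what a longer chain on that oxygen, such as ethoxy or a chain ending in an amine, would give.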